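The source may hold more compounds than are shown below. What is called first, only, known or untested is meant among the compounds shown, and "the series" means these compounds.

Compound 1 `CC(C)[C@H](NC(=O)COc1cccc2ccccc12)C(=O)N[C@@H](CC(=O)O)C(=O)COc1ccc(-c2ccccc2)cc1` gives 87900 nM in a functional assay on Jurkat cells (Homo sapiens); on this read-out lower numbers stand for stronger inhibition and higher numbers for weaker inhibition. Compound 2 `CC(C)[C@H](NC(=O)COc1cccc2ccccc12)C(=O)N[C@@H](CC(=O)O)C(=O)COc1ccc(C(N)=O)cc1` reaches only the limit of this assay, > 100000 nM. Compound 3 `CC(C)[C@H](NC(=O)COc1cccc2ccccc12)C(=O)N[C@@H](CC(=O)O)C(=O)COc1ccc(F)c(F)c1F` gives 35800 nM.

Compound 2 thus stands at the weak end of the numbers shown, with a limit rather than a measured value. Compound 4 `CC(C)[C@H](NC(=O)COc1cccc2ccccc12)C(=O)N[C@@H](CC(=O)O)C(=O)COc1c(Cl)cccc1Cl` differs from it in one place: 2,6-dichlorophenyl in place of 4-carbamoylphenyl on an oxygen on a saturated carbon. For the measured compounds named here, one measured step bears on this: an at least 2.7-fold lower number from compound 2 to compound 3 (0.44 log units; beyond the scatter), where 2,3,4-trifluorophenyl replaced the same 4-carbamoylphenyl group; by contrast an at least 1.1-fold higher number from compound 1 to compound 2 (0.05 log units; that floor lies within the scatter) lies within the scatter. A drop of similar, modest size is therefore expected here, an at least 2.5-fold lower number from compound 2 to compound 4 (0.39 log units; beyond the scatter). Compound 4 is estimated at 40000 nM, within a range from 15000 nM to 100000 nM.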

Compound 4, half-maximal inhibitory concentration: 3000 nM
Compound 4: the middle estimate sits 13-fold (1.12 log units) above what was measured; measured number below the stated range.
By their numbers in this assay, from the lowest: compound 4; then compound 3; then compound 1. At a limit, above all of these: compound 2.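

At this position, on the oxygen on a saturated carbon, changing the ring can do far more than the modest steps seen earlier suggested in this assay, with a 12-fold lower number from compound 3 to compound 4 (1.08 log units; beyond the scatter) and a 29-fold lower number from compound 1 to compound 4 (1.47 log units; beyond the scatter). Halogens on the ring are not enough by themselves, as 2,3,4-trifluorophenyl stays well behind 2,6-dichlorophenyl. Compound 2 sits at a limit, so an at least 33-fold lower number from compound 2 to compound 4 (1.52 log units; beyond the scatter) gives only a floor: the limit of > 100000 nM in this assay, at which 1 of the 4 values shown sits.

From the compounds shown here alone, what stays open is whether the chlorines themselves matter or only the pattern of substitution. A 2,6-dimethylphenyl or 2,6-difluorophenyl group at the same place would separate the two.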